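The source may report more compounds than this note shows. Statements on the series, on what has been measured and on what is new or still open speak of the compounds shown alone.

In a physicochemical assay for lipophilicity, read by HPLC, measured as chromatographic lipophilicity, at pH 7.4 (on this read-out higher numbers stand for higher lipophilicity and lower numbers for lower lipophilicity), three compounds have been measured so far:

Compound 1 (`O=C(C1CCC1)N1N=CCC1c1ccccc1`) reads 4.7
Compound 2 (`CC(C)(CN)C(=O)N1N=CCC1c1ccccc1`) reads 1.4
Compound 3 (`O=C(c1ccccc1)N1N=CCC1c1ccccc1`) reads 4.6

Compound 3 stands high on this short scale. Phenyl in place of cyclobutyl on a carbonyl carbon made no difference beyond the scatter (a number 0.10 log units lower from compound 1 to compound 3 (within the scatter)). Phenyl in place of 1-(aminomethyl)-1-methylethyl, by contrast, gave a large change (a number 3.20 log units higher from compound 2 to compound 3 (beyond the scatter)), matched by the large change on the other side (a number 3.30 log units lower from compound 1 to compound 2 (beyond the scatter)).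

The next compound is compound 4 (`O=C(c1ccccn1)N1N=CCC1c1ccccc1`), which carries pyridin-2-yl in place of phenyl on a carbonyl carbon. For the measured compounds named here, no measured step makes this exact swap. The two large steps both turn on 1-(aminomethyl)-1-methylethyl, which plays no part here, so they set only an outer bound. The swap between cyclobutyl and phenyl (a number 0.10 log units lower from compound 1 to compound 3 (within the scatter)) is the closer comparison, but it brings in no hetero atom, whereas here a hydrogen-bond acceptor enters. With compound 3 at 4.6 as the starting point, a moderate fall is therefore expected in this assay rather than no change. The expected step is an estimated a number 0.90 log units lower from compound 3 to compound 4 (beyond the scatter) and so lies beyond the scatter but well short of the large steps. Compound 4 is estimated at 3.7 with an expected range from 3.2 to 4.2 on this scale.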

Compound 4, distribution coefficient: 2.4
Compound 4: middle estimate off by 1.30 log units, on the high side; measured number below the stated range.
By their numbers in this assay, from the lowest: compound 2; then compound 4; then compounds 3 and 1 (each within the scatter of the next).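

At this place, on a carbonyl carbon whose other neighbours are an amide-type nitrogen in a ring, this assay did not respond alike to every six-membered aromatic or small cyclic group: the exchange of cyclobutyl for phenyl had stayed within the scatter, yet pyridin-2-yl, with the same heavy-atom count as phenyl, one ring nitrogen in place of one carbon, one hydrogen-bond acceptor and no net charge, gives a number 2.20 log units lower from compound 3 to compound 4 (beyond the scatter) and, measured against cyclobutyl, a number 2.30 log units lower from compound 1 to compound 4 (beyond the scatter) as well. The large steps are thus no longer tied to 1-(aminomethyl)-1-methylethyl, although that group still sits apart from pyridin-2-yl, with a number 1.00 log units higher from compound 2 to compound 4 (beyond the scatter) in the same assay. Nothing available here accounts for the size of this change.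

Going by these compounds, whether the same result would come with pyridin-3-yl or pyridin-4-yl, which carry the ring nitrogen elsewhere, remains open. So does the reading for a ring with a second nitrogen, such as pyrimidinyl, or for a saturated ring with a nitrogen, such as piperidinyl, at this carbonyl carbon.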